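The compounds below may be only part of what the source reports. "The series", "measured", "known", "first", "only" and "open" are said of these compounds alone.

In a functional assay on HEK293 cells for agonist activity at Glucose-dependent insulinotropic receptor (Homo sapiens), read by cAMP accumulation, with a stated time of 30 min (a higher number here means a larger maximal response, a lower number a smaller maximal response), compound 1 `CC1(OC(=O)N2C[C@H]3COC[C@@H](C2)[C@@H]3Oc2ncnc(Nc3ccc(C#N)cc3Cl)c2F)CC1` gives 92%, the higher of the two values recorded so far. Compound 2 `CC1(OC(=O)N2CC3COCC(C2)C3Oc2ncnc(Nc3ccc(-n4cncn4)cc3F)c2F)CC1` gives 73% in this assay, a value that falls beyond the scatter below that of compound 1. Compound 3 `CC1(OC(=O)N2C[C@H]3COC[C@@H](C2)[C@@H]3Oc2ncnc(Nc3c(F)cccc3F)c2F)CC1` has not yet been measured; it differs from compound 1 by 2,6-difluorophenyl in place of 2-chloro-4-cyanophenyl on a nitrogen on an aromatic ring. Among the compounds with values here, no measured pair shows this same change, so any expectation rests only on the spread between compound 1 and compound 2. Compound 3 is expected to give about 80% in this assay, with a range from 55% to 100%. The expected step of a number 12 percentage points lower from compound 1 to compound 3 (beyond the scatter) is a modest decrease that may sit near the edge of the scatter.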

Compound 3, largest response reached (reported as percent of maximum), in percent of the reference or control that the assay uses: 78%
Compound 3: middle estimate off by 2 percentage points, on the high side; low and high end bracket the measured number.
By their numbers in this assay, from the lowest: compounds 2 and 3 (each within the scatter of the next); then compound 1.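

In this assay, 2,6-difluorophenyl in place of 2-chloro-4-cyanophenyl on a nitrogen on an aromatic ring gives a number 14 percentage points lower from compound 1 to compound 3 (beyond the scatter). Within the data shown here, this is the first reading of this position alone with the rest of compound 1 unchanged, and it shows that a substantial response persists without the nitrile and the chlorine, though the change is not neutral. Nothing measured here bears on why the response shifts.

The compounds shown do not separate the contribution of the nitrile from that of the chlorine. On these data alone, how a phenyl ring carrying an amine or a carboxylic acid would fare on this nitrogen also remains open.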